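The source may hold more compounds than are shown below. What is called first, only, known or untested is meant among the compounds shown, and "the series" means these compounds.

Series notes: in a functional assay on CCRF-CEM cells (Homo sapiens) for inhibition (on this read-out higher numbers stand for weaker inhibition and lower numbers for stronger inhibition), compound 1 `Cn1cc(C#N)c2ccc(Nc3ncc(-c4ccccc4)o3)cc21` gives 8000 nM, and compound 2 `Cn1cc(C#N)c2ccc(Nc3ncc(-c4ccccc4CN)o3)cc21` gives 1100 nM, the lower of the two numbers so far. Next is compound 3 `Cn1cc(C#N)c2ccc(Nc3ncc(-c4ccccc4CNC(=O)OCCC#N)o3)cc21`, which differs from compound 2 by (2-cyanoethoxy)carbonyl in place of hydrogen on an amine nitrogen. For the measured compounds named here, one measured step bears on this change: a 7.3-fold lower number from compound 1 to compound 2 (0.86 log units; beyond the scatter), with aminomethyl in place of hydrogen on an aromatic carbon. Going by the values given here, compound 3 keeps that aminomethyl but carries the new group on its nitrogen, and no measured compound shows such a substitution. In this assay, a move back toward compound 1 at 8000 nM is therefore expected, somewhat smaller than that step and quite uncertain. The expected change is a 3.6-fold higher number from compound 2 to compound 3 (0.56 log units; beyond the scatter). Compound 3 is estimated at 4000 nM, with an expected range of 1200 nM to 13000 nM.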

Compound 3, half-maximal inhibitory concentration: > 10000 nM
Compound 3 ended at the assay's limit (the forecaster's own chance of this, stated with the estimate: 12%); middle value at least 2.5-fold (0.39 log units) from the limit.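

In this assay compound 3 reads > 10000 nM, which is a limit of the assay and not a number. Placing (2-cyanoethoxy)carbonyl on the amine nitrogen gives an at least 9.0-fold higher number from compound 2 to compound 3 (0.95 log units; beyond the scatter), so the gain seen with the free aminomethyl in a 7.3-fold lower number from compound 1 to compound 2 (0.86 log units; beyond the scatter) does not carry over to this substituted form, something the earlier compounds could not show. Against the compound without the side chain, the reading is an at least 1.2-fold higher number from compound 1 to compound 3 (0.09 log units; that floor lies within the scatter); this floor allows no firm ordering of the two, and the true gap is unknown.

The compounds shown leave open whether any group on this nitrogen gives such a step or only this one. A methyl or an acetyl on the nitrogen, or a longer chain between the aromatic carbon and the amine, would test the question.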